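The source may hold more compounds than are shown below. What is called first, only, known or untested is meant among the compounds shown, and "the series" means these compounds.

Of the compounds shown here, three have so far been measured in an assay on membranes from brain for binding affinity to neutral cholesterol ester hydrolase 1 (Mus musculus), read by fluorescence, with stated times of 1 h and 30 min (a lower number here means a stronger inhibitor, a higher number a weaker inhibitor), and each of them returned only a limit. Compound 1 `N#Cc1cnn(C(=O)NCc2ccc(OC(c3ccccc3)c3ccccc3)cc2)c1` gives > 100000 nM, which is a limit of the assay and not a number. Compound 2 `Cc1cnn(C(=O)N2CCN(C(c3ccc4ccccc4c3)c3ccc4ccccc4c3)CC2)c1` gives > 100000 nM, again a limit. Compound 3 `O=C(N1CCN(C(c2ccc3ccccc3c2)c2ccc3ccccc3c2)CC1)n1cccn1` gives > 100000 nM, once more a limit. Within the data shown here, the single measured step, hydrogen in place of methyl on an aromatic carbon, a step that the two limits leave unreadable from compound 2 to compound 3, cannot be read because of the limit of > 100000 nM in this assay, at which 3 of the 3 values shown sit. Compound 3 therefore stands at a limit, without a number of its own to build on.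

Compound 4 `N#Cc1cnn(C(=O)N2CCN(C(c3ccc4ccccc4c3)c3ccc4ccccc4c3)CC2)c1` differs from compound 3 by cyano in place of hydrogen on an aromatic carbon, in words cyano in place of hydrogen on an aromatic carbon. Among the measured compounds shown here, no measured step carries a cyano entering, and the one step that exists is itself unreadable. Compound 1, which bears the same 4-cyano-1H-pyrazol-1-yl group on a different amide partner, also shows only the limit > 100000 nM. Compound 4 is therefore expected to remain at the limit as well, with an estimated 100000 nM and a range from 30000 nM to 300000 nM. For compound 4 the expected step is a number no higher from compound 3 to compound 4 (the limit leaves the size open), none beyond the scatter.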

Compound 4, half-maximal inhibitory concentration: > 100000 nM
Compound 4: a limit, no number; the forecaster's own chance of this, stated with the estimate: 85%; the middle value lies on the limit itself.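

Compound 4 gives > 100000 nM in this assay, which is a limit of the assay and not a number. No new step can be read from compound 4 to compound 3 or compound 2 because all of them sit at the same limit: the limit of > 100000 nM in this assay, at which 4 of the 4 values shown sit. The compounds shown leave open whether hydrogen, methyl or cyano at this place differ at all in this assay.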